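From One Carboxy Amide to Its Isomer

This account rests on a few compounds, and the source may have more. Where it says the series, first, only, none or still open, it means among the compounds named here.

Within the data shown here, in a functional assay on Caco-2 cells (Homo sapiens) for antiproliferative activity, read by MTT assay, with a stated time of 48 h (a lower number here means a stronger inhibitor, a higher number a weaker inhibitor), compound 2 `CCn1c(C(=O)N(C)CC(=O)O)ccc1C(CC)(CC)c1ccc(OCCC(O)(CC)CC)c(C)c1` gives 2740 nM, the only actual number available so far. Compound 1 `CCn1c(C(=O)NCC#N)ccc1C(CC)(CC)c1ccc(OCCC(O)(CC)CC)c(C)c1` gives > 50000 nM, and this value is a limit of the assay. Among the measured compounds shown here, the single measured step is large: an at least 18-fold lower number from compound 1 to compound 2 (1.26 log units; beyond the scatter).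

Compound 3 `CCn1c(C(=O)NC(C)C(=O)O)ccc1C(CC)(CC)c1ccc(OCCC(O)(CC)CC)c(C)c1` has the same atoms as compound 2, joined differently, with (1-carboxyethyl)amino in place of (carboxymethyl)(methyl)amino on a carbonyl carbon. The measured step bears on this change only loosely. It replaced (cyanomethyl)amino, a group absent from compound 3, and it reaches a limit at one end. Compound 2, at 2740 nM, remains the closest reference, since both it and compound 3 carry a carboxy group on the amide. For the measured compounds named here, no measured step exchanges one such group for another, so no shift beyond the scatter is expected in this assay, although the uncertainty is wide. The expected change is a 1.1-fold higher number from compound 2 to compound 3 (0.04 log units; within the scatter). The estimated value for compound 3 is 3000 nM, with an expected range of 900 nM to 12000 nM.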

Compound 3, half-maximal inhibitory concentration: 46500 nM
For compound 3 the middle estimate is 16-fold (1.19 log units) below the measured one, and the stated range ends below it.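

The same six heavy atoms, rearranged on a carbonyl carbon, separate two carboxy amides in this assay: (1-carboxyethyl)amino in place of (carboxymethyl)(methyl)amino gives a 17-fold higher number from compound 2 to compound 3 (1.23 log units; beyond the scatter). A carboxy group on the amide therefore does not by itself bring the lower number of compound 2; how the group is joined to the amide also matters in this assay. With 1-carboxyethyl in place of cyanomethyl on the amide-type nitrogen, the comparison reads an at least 1.0-fold lower number from compound 1 to compound 3 (0.03 log units; that floor lies within the scatter), and compound 3 cannot be ranked against compound 1 from this step, as it rests on a limit of the assay: the limit of > 50000 nM in this assay, at which 1 of the 3 values shown sits.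

The compounds shown leave open whether the gap between compound 2 and compound 3 follows the methyl on the amide nitrogen or the methyl on the chain, a question that (carboxymethyl)amino, carrying neither methyl, would address directly. They also leave open whether (cyanomethyl)(methyl)amino would keep the lower number without a carboxylic acid, and how a longer chain between the amide nitrogen and the carboxylic acid would read.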